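A few compounds are considered here, and "the series" means these few. Any claim that something is new, unique, unknown or untested is made for them only; others in the source may bear on it.

Series notes. Compound 1 `CN1CCC[C@H]1[C@H]1COc2ccc([N+](=O)[O-])cc2O1` and compound 3 `CN1CCC[C@H]1[C@H]1COc2ccc(O)cc2O1` share a core; the difference between them is hydroxy in place of nitro on an aromatic carbon. Compound 2 `CN1CCC[C@H]1[C@@H]1COc2cc([N+](=O)[O-])ccc2O1` has the same atoms as compound 1 joined differently; the difference between the two cores is not broken down here. Compound 4 `CN1CCC[C@H]1[C@@H]1COc2cc(O)ccc2O1` stands to compound 2 as compound 3 stands to compound 1: hydroxy in place of nitro on an aromatic carbon, the same change at the same kind of place.

In an assay on membranes from HEK293 cells for displacement of a labelled ligand from Neuronal acetylcholine receptor; alpha3/beta4 (Homo sapiens), with a stated time of 5 min (on this read-out lower numbers stand for stronger inhibition and higher numbers for weaker inhibition), compound 1 gives 2100 nM, compound 2 gives 15000 nM and compound 3 gives 700 nM. The measured step is a 3.0-fold lower number from compound 1 to compound 3 (0.48 log units; beyond the scatter). Compound 2 sits highest of the three numbers.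

Compound 4 is not yet measured in this assay. For the measured compounds named here, for compound 4 the expected step is a 3.0-fold lower number from compound 2 to compound 4 (0.48 log units; beyond the scatter), resting on a 3.0-fold lower number from compound 1 to compound 3 (0.48 log units; beyond the scatter) as the only precedent for this change. Compound 4 is therefore expected near 5000 nM. The expected range for compound 4 runs from 2000 nM to 12000 nM.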

Compound 4, inhibition constant: 1900 nM
For compound 4 the middle estimate is 2.6-fold (0.42 log units) above the measured one; measured number outside the range, below it.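

Hydroxy in place of nitro on an aromatic carbon moves the number the same way on both cores in this assay, the new step being a 7.9-fold lower number from compound 2 to compound 4 (0.90 log units; beyond the scatter). Set beside the earlier step, the two do not separate in size: the same change on two cores in this assay, a 3.0-fold lower number (0.48 log units; beyond the scatter) from compound 1 to compound 3 and a 7.9-fold lower number (0.90 log units; beyond the scatter) from compound 2 to compound 4, 2.6-fold (0.42 log units) apart, within the scatter of two such steps. For the compounds shown here, with only two pairs, this supports carrying the change between these two cores in this assay, but it does not show that the change would carry to any other core or to another place on the aromatic ring.

Still open, on these data alone, is whether an amine or a methoxy group on the same aromatic carbon would follow the same course. Also open, as far as these compounds go, is whether both steps would hold on other receptor subtypes.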